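The compounds below may be only part of what the source reports. "The series", "measured", "known", "first", "only" and "open" are said of these compounds alone.

Measured compounds:
- compound 1 `Cc1ccc(S/C(=C/c2c(O)cc(O)cc2O)C(=O)c2ccc(Cl)cc2)cc1`: > 100000 nM
- compound 2 `O=C(/C(=C\c1c(O)cc(O)cc1O)SCc1ccc(Cl)c(Cl)c1)c1ccc(Cl)cc1`: 25000 nM
- compound 3 `O=C(/C(=C\c1c(O)cc(O)cc1O)S(=O)(=O)c1ccc(Br)cc1)c1ccc(Cl)cc1`: > 100000 nM

In a functional assay on DU-145 cells (Homo sapiens) for inhibition, read by trypan blue exclusion, with a stated time of 96 h (on this read-out higher numbers stand for weaker inhibition of growth and lower numbers for stronger inhibition of growth), compound 1 gives only a limit, > 100000 nM, not a number. In this assay compound 2 gives 25000 nM. Compound 3 also sits at a limit in this assay, > 100000 nM. Compound 1 therefore stands at the weak end of what is shown, together with compound 3, as the limit of > 100000 nM in this assay, at which 2 of the 3 values shown sit, records. The measured steps all concern the substituent on the sulfur: an at least 4.0-fold lower number from compound 1 to compound 2 (0.60 log units; beyond the scatter), an at least 4.0-fold higher number from compound 2 to compound 3 (0.60 log units; beyond the scatter), and a step that the two limits leave unreadable from compound 1 to compound 3. None of them alters the aryl on the chain carbon.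

Compound 4 `COc1ccccc1/C=C(/Sc1ccc(C)cc1)C(=O)c1ccc(Cl)cc1` differs from compound 1 in exactly that untouched place: 2-methoxyphenyl in place of 2,4,6-trihydroxyphenyl on a double-bonded chain carbon bound to a double-bonded chain carbon. Going by the values given here, no measured step in this assay touches this part of the shared core, so no size or direction of the step can be read from the data; the only anchor is that compound 1 itself stands at the limit. The working expectation is that compound 4 stays near that limit, with the step of a number no higher from compound 1 to compound 4 (the limit leaves the size open) expected to be small or not resolvable. Compound 4 is estimated at 100000 nM, with a range from 30000 nM to 300000 nM, and a real chance that only a limit is reported.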

Compound 4, concentration for 50% growth inhibition: 25000 nM
Estimate against measurement, compound 4: 4.0-fold (0.60 log units) above, outside the stated range (below it).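

With the (4-methylphenyl)sulfanyl group held fixed, 2-methoxyphenyl in place of 2,4,6-trihydroxyphenyl gives an at least 4.0-fold lower number from compound 1 to compound 4 (0.60 log units; beyond the scatter) in this assay, so the aryl on the double-bonded chain carbon, and not only the substituent on the sulfur, moves this read-out. The pair also shows that growth inhibition at this level does not depend on the hydroxyl groups of 2,4,6-trihydroxyphenyl, as the 2-methoxyphenyl group that replaces it carries no hydrogen-bond donors. Compound 1 enters this step only as a limit, so the full size of the step stays open: the limit of > 100000 nM in this assay, at which 2 of the 4 values shown sit.

The compounds shown do not separate the loss of the hydroxyl groups from the entry of the methoxy group, and they leave open how an amine or a carboxylic acid on this aryl would read. Also open, as far as these compounds go, is whether 2-methoxyphenyl and a (3,4-dichlorobenzyl)sulfanyl group, each of which gives a lower number than compound 1 in its own single change, would add up when carried together on the shared core.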